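Dropping the chloro from compound 1: what to expect

A few compounds are considered here, and "the series" means these few. Any claim that something is new, unique, unknown or untested is made for them only; others in the source may bear on it.

Measured so far:
compound 1, `Cc1c(/N=C/c2ccccc2Cl)c(=O)n(-c2ccccc2)n1C`, 309000000 nM
compound 2, `COc1ccc(/C=N/c2c(C)n(C)n(-c3ccccc3)c2=O)cc1OC`, 603000000 nM

Both were tested in a functional assay on HT-29 cells (Homo sapiens) for cytotoxicity, read by MTT assay, with a stated time of 72 h; a lower number here means a stronger inhibitor, a higher number a weaker inhibitor. Compound 1 and compound 2 give numbers that lie within the usual scatter of each other, so no difference between them can be claimed, and compound 1 stands simply as one of two very weak inhibitors. Compound 3, `Cc1c(/N=C/c2ccccc2)c(=O)n(-c2ccccc2)n1C`, is not yet measured. It differs from compound 1 by hydrogen in place of chloro on an aromatic carbon. For the measured compounds named here, no pair of measured compounds shows such a change, so there is nothing to set a size to it; the expected step in this assay, a 1.3-fold higher number from compound 1 to compound 3 (0.11 log units; within the scatter), is none beyond the scatter. For compound 3 the expected value is therefore 400000000 nM, ranging from 100000000 nM to 1500000000 nM.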

Compound 3, half-maximal inhibitory concentration: 851000000 nM
The estimate for compound 3 lay 2.1-fold (0.33 log units) below the measured number, and the stated range covers the measured number.
By their numbers in this assay, from the lowest: compounds 1, 2 and 3 (each within the scatter of the next, the first and the last beyond it).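

In this assay, putting hydrogen in place of chloro on this aromatic carbon, ortho to a large group, gives a 2.8-fold higher number from compound 1 to compound 3 (0.44 log units; beyond the scatter) as the first measured size for this change. The chloro therefore counts for something at this place, although the step is modest and all these compounds remain very weak inhibitors. Nothing available explains why the step occurs.

Still open, from the compounds shown here alone, is whether the step is specific to chloro or would also appear with fluoro, bromo, methyl or an amine on the same carbon. Going by these compounds, whether moving the chloro elsewhere on the ring would preserve the step is also open.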